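Removing one methoxy from a weak antiproliferative hydrazone

The source may report more compounds than this note shows. Statements on the series, on what has been measured and on what is new or still open speak of the compounds shown alone.

Measured so far:
Compound 1, `Cn1c(=O)c(=O)n(C2CCCC2)c2nc(N/N=C/c3ccco3)ncc21`: in a functional assay on PC-3 cells (Homo sapiens) for antiproliferative activity, read by MTT assay (a higher number here means a weaker inhibitor, a lower number a stronger inhibitor), compound 1 gives 72200 nM.
Compound 2, `COc1ccc(/C=N/Nc2ncc3c(n2)n(C2CCCC2)c(=O)c(=O)n3C)c(OC)c1`: in this assay compound 2 reaches only the limit > 100000 nM, which is not a number.

Compound 2 thus stands at the weak end of the two values shown, and only a limit is known for it; this is the limit (the limit of > 100000 nM in this assay, at which 1 of the 2 values shown sits). Among the measured compounds shown here, the one measured step, an at least 1.3-fold higher number from compound 1 to compound 2 (0.14 log units; that floor lies within the scatter), replaced furan-2-yl with 2,4-dimethoxyphenyl, and its floor lies within the scatter, so it says little about direction.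

Compound 3, `COc1ccc(/C=N/Nc2ncc3c(n2)n(C2CCCC2)c(=O)c(=O)n3C)cc1`, differs from compound 2 by hydrogen in place of methoxy on an aromatic carbon, that is, 2,4-dimethoxyphenyl becomes 4-methoxyphenyl. For the measured compounds named here, no measured step removes a methoxy, so the only guide is that compound 2 already sits at the limit in this assay. Compound 3 is therefore expected to remain weak, with a step that the limit leaves unreadable from compound 2 to compound 3, not beyond the scatter. The estimate for compound 3 in this assay is 120000 nM, within a range from 40000 nM to 400000 nM.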

Compound 3, half-maximal inhibitory concentration: 26300 nM
Beside the measured number, compound 3's estimate is 4.6-fold (0.66 log units) above it, outside the stated range (below it).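

In this assay, among the compounds shown here, removing the methoxy ortho to a large group gives an at least 3.8-fold lower number from compound 2 to compound 3 (0.58 log units; beyond the scatter), so this position on the ring can move the number beyond the scatter, which the earlier compounds could not show. The true size of this step is unknown, because compound 2 is known only through a limit: the limit of > 100000 nM in this assay, at which 1 of the 3 values shown sits.

The comparison with the furan also becomes readable, with a 2.7-fold lower number from compound 1 to compound 3 (0.44 log units; beyond the scatter), whereas the floor of the step from furan-2-yl to 2,4-dimethoxyphenyl lay within the scatter and gave no direction; the aromatic group on the carbon with a double bond to nitrogen can therefore shift the result in either compound pair only as far as these two steps show.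

The compounds shown leave open whether the remaining methoxy helps at all, since a plain phenyl, or a phenyl carrying a chlorine or an amine in its place, would be needed to answer that. They also leave open whether this single gain would hold on a different core, as it rests on one pair of compounds in one cell line.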